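Saturating the linker of compound 1

A few compounds are considered here, and "the series" means these few. Any claim that something is new, unique, unknown or untested is made for them only; others in the source may bear on it.

Going by the values given here, compound 1 `O=C(CCCCC#Cc1cccnc1)c1ncc(-c2ccccn2)o1` stands at the top of the three numbers measured so far in an assay for inhibition of Fatty-acid amide hydrolase 1 (Rattus norvegicus) (on this read-out lower numbers stand for stronger inhibition and higher numbers for weaker inhibition), where compound 1 gives 300 nM. Nearest to it is compound 3 `O=C(CCCCC#Cc1ccc([N+](=O)[O-])cc1)c1ncc(-c2ccccn2)o1`, which in this assay gives 31 nM, and furthest from it is compound 2 `O=C(CCCCC#Cc1ccc(Cl)cc1)c1ncc(-c2ccccn2)o1`, which in this assay gives 20 nM. The steps known so far all alter the aromatic group on the triple-bonded carbon: a 15-fold lower number from compound 1 to compound 2 (1.18 log units; beyond the scatter), a 9.7-fold lower number from compound 1 to compound 3 (0.99 log units; beyond the scatter), and a 1.6-fold higher number from compound 2 to compound 3 (0.19 log units; within the scatter).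

Compound 4 `O=C(CCCCCCc1cccnc1)c1ncc(-c2ccccn2)o1` differs from compound 1 in another place: 2-(pyridin-3-yl)ethyl in place of 2-(pyridin-3-yl)ethynyl on a saturated chain carbon, four bonds along the chain from a carbonyl carbon. Among the compounds with values here, none of the measured steps touches the chain itself; each keeps the triple bond and changes only the ring at its end, so they give no direct guide to the size of this step. With the same ring retained and only the chain altered, a modest shift is expected rather than a large one. Compound 4 is expected to show a 2.5-fold lower number from compound 1 to compound 4 (0.40 log units; beyond the scatter), a step not clearly beyond the scatter. The estimate for compound 4 in this assay is therefore 120 nM, with a range from 35 nM to 500 nM.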

Compound 4, inhibition constant: 32 nM
Compound 4: middle estimate off by 3.8-fold (0.57 log units), on the high side, outside the stated range (below it).
By their numbers in this assay, from the lowest: compounds 2, 3 and 4 (each within the scatter of the next); then compound 1.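

The chain itself proves to be a sensitive position in this assay: with the pyridin-3-yl ring kept, 2-(pyridin-3-yl)ethyl in place of 2-(pyridin-3-yl)ethynyl gives a 9.4-fold lower number from compound 1 to compound 4 (0.97 log units; beyond the scatter). The earlier steps shown here all kept the triple bond and changed only the ring, so they could not show that this bond can be given up without any loss, or that the high number of compound 1 depends on the chain as well as on the pyridin-3-yl ring. No measurement at hand accounts for the size of this step.

The compounds shown leave open whether the gains from the 4-chlorophenyl and 4-nitrophenyl groups seen with the triple bond would carry over to the saturated chain, or whether the two changes would add together at all. They also leave open how a carbon-carbon double bond at the same place in the chain, a shorter or longer chain, or an amine or carboxylic acid on the ring at its end would read in this assay.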